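Thiophene to furan swap on the shared core

The source may hold more compounds than are shown below. What is called first, only, known or untested is meant among the compounds shown, and "the series" means these compounds.

Measured so far:
compound 1 `COc1ncnc2c1c(-c1ccsc1)cn2[C@@H]1O[C@H](CO)[C@@H](O)[C@H]1O` — 7640 nM
compound 2 `CSc1ncnc2c1c(-c1ccsc1)cn2[C@@H]1O[C@H](CO)[C@@H](O)[C@H]1O` — > 20000 nM

For the measured compounds named here, in a functional assay on CEM-DNR-bulk cells (Homo sapiens), read by MTT assay, with a stated time of 72 h (on this read-out lower numbers stand for stronger inhibition and higher numbers for weaker inhibition), compound 1 gives 7640 nM, the only plain number in the set. For compound 2 the assay reports only a limit, > 20000 nM. Going by the values given here, the one measured step, an at least 2.6-fold higher number from compound 1 to compound 2 (0.41 log units; beyond the scatter), goes with methylsulfanyl in place of methoxy on an aromatic carbon and rests on (the limit of > 20000 nM in this assay, at which 1 of the 2 values shown sits).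

Compound 3 `COc1ncnc2c1c(-c1ccco1)cn2[C@@H]1O[C@H](CO)[C@@H](O)[C@H]1O` differs from compound 1 in a different place: furan-2-yl in place of thiophen-3-yl on an aromatic carbon. Among the compounds with values here, no measured step touches this position, so the step from compound 1 to compound 2 gives no direct guide, and the change is read as a like-for-like exchange of one five-membered aromatic ring with 1 hetero atom for another. The expectation is therefore a step of a 1.1-fold higher number from compound 1 to compound 3 (0.05 log units; within the scatter), no clear direction beyond the scatter. Compound 3 is estimated at 8500 nM, between 2500 nM and 25000 nM.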

Compound 3, half-maximal inhibitory concentration: 160 nM
Beside the measured number, compound 3's estimate is 53-fold (1.73 log units) above it; measured number outside the range, below it.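

In this assay furan-2-yl in place of thiophen-3-yl goes with a 48-fold lower number from compound 1 to compound 3 (1.68 log units; beyond the scatter) and so marks this ring position as a strong determinant of the read-out, which the step at the methoxy carbon could not show. The two rings have the same counts of heavy atoms, hydrogen-bond donors and acceptors and the same lack of net charge, so those counts do not separate them. What remains different is the hetero atom, oxygen for sulfur, and the ring atom of attachment, and nothing at hand gives a cause for the step.

The compounds shown leave open whether the hetero atom or the attachment carries the step, a question that furan-3-yl and thiophen-2-yl on the shared core would separate. Also open, from the compounds shown here alone, is whether furan-2-yl keeps this effect with methylsulfanyl in place of methoxy.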